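Notes on the series: trifluoromethyl substitution at the aryl-thiazole

The source may report more compounds than this note shows. Statements on the series, on what has been measured and on what is new or still open speak of the compounds shown alone.

Measured compounds in a functional assay on MCF7 cells (Homo sapiens) for antiproliferative activity, read by MTT assay, with a stated time of 48 h; a higher number here means a weaker inhibitor, a lower number a stronger inhibitor:
- compound 1 `COc1ccc(C2=NN(c3nc(-c4ccc(C(F)(F)F)cc4)cs3)C(c3cccs3)C2)cc1`: 45700 nM
- compound 2 `Fc1ccc(C2=NN(c3nc(-c4ccc(Br)cc4)cs3)C(c3cccs3)C2)cc1`: 8280 nM
- compound 3 `Fc1ccc(C2=NN(c3nc(-c4ccccc4)cs3)C(c3cccs3)C2)cc1`: 2340 nM

Compound 3 gives the lowest number of the three; compound 2 is its nearest neighbour and compound 1 the furthest. Compound 4 `Fc1ccc(C2=NN(c3nc(-c4ccc(C(F)(F)F)cc4)cs3)C(c3cccs3)C2)cc1` differs from compound 3 by trifluoromethyl in place of hydrogen on an aromatic carbon. For the measured compounds named here, the only measured step at this position is a 3.5-fold lower number from compound 2 to compound 3 (0.55 log units; beyond the scatter), where removing a substituent on this aromatic carbon lowered the number. Reversing that, and noting that compound 1, which also carries trifluoromethyl there, gives 45700 nM, a higher number is expected for compound 4 in this assay. The estimated step is a 4.3-fold higher number from compound 3 to compound 4 (0.63 log units; beyond the scatter). Compound 4 is expected at 10000 nM, range 3000 nM to 35000 nM.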

Compound 4, half-maximal inhibitory concentration: 1330 nM
The estimate for compound 4 lay 7.5-fold (0.88 log units) above the measured number; measured number outside the range, below it.
By their numbers in this assay, from the lowest: compounds 4 and 3 (each within the scatter of the next); then compound 2; then compound 1.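

In this assay, a 1.8-fold lower number from compound 3 to compound 4 (0.25 log units; within the scatter) lies within the scatter, so trifluoromethyl and hydrogen on this aromatic carbon are not separated. Bromo and trifluoromethyl are separated, with a 6.2-fold lower number from compound 2 to compound 4 (0.79 log units; beyond the scatter), so a substituent at this carbon does not by itself bring a higher number. With trifluoromethyl held constant, a 34-fold lower number from compound 1 to compound 4 (1.54 log units; beyond the scatter) ties the high number of compound 1 to methoxy in place of fluoro, not to trifluoromethyl.

Going by these compounds, whether an amine or a carboxylic acid on this carbon would group with hydrogen and trifluoromethyl or with bromo remains open. Nothing shown accounts for the gap between bromo and trifluoromethyl.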